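Chloro in place of methoxy on the shared core

The source may report more compounds than this note shows. Statements on the series, on what has been measured and on what is new or still open speak of the compounds shown alone.

In a functional assay on HUVEC cells (Homo sapiens) for inhibition, using NADPH, with a stated time of 2 h (on this read-out lower numbers stand for stronger inhibition and higher numbers for weaker inhibition), compound 1 `Cc1c(COc2cccc(OCC3CCOCC3)c2)[nH]c2ccccc2c1=O` gives 8.9 nM, and compound 2 `Cc1ccc2[nH]c(COc3cccc(OCC4CCOCC4)c3)c(C)c(=O)c2c1` gives 38 nM. Compound 3 `COc1ccc2[nH]c(COc3cccc(OCC4CCOCC4)c3)c(C)c(=O)c2c1` gives > 10000 nM, which is a limit of the assay and not a number. Compound 4 `Cc1c(COc2cccc(OCC3CCOCC3)c2)[nH]c2ccc(Cl)cc2c1=O` carries chloro in place of methoxy on an aromatic carbon. Among the measured compounds shown here, three measured steps bear on this change. Methyl in place of hydrogen gave a 4.3-fold higher number from compound 1 to compound 2 (0.63 log units; beyond the scatter). Methoxy in place of hydrogen gave an at least 1100-fold higher number from compound 1 to compound 3 (3.05 log units; beyond the scatter). Methoxy in place of methyl gave an at least 260-fold higher number from compound 2 to compound 3 (2.42 log units; beyond the scatter). With methoxy gone, a large step to a lower number is expected in this assay, with compound 2 at 38 nM as the nearest guide. The expected step is an at least 250-fold lower number from compound 3 to compound 4 (2.39 log units; beyond the scatter). For compound 4 the estimate is 40 nM, with an expected range of 8 nM to 300 nM.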

Compound 4, half-maximal inhibitory concentration in the HUVEC assay: 5 nM
Beside the measured number, compound 4's estimate is 8.0-fold (0.90 log units) above it; the whole stated range lies above it.
By their numbers in the HUVEC assay, from the lowest: compounds 4 and 1 (each within the scatter of the next); then compound 2. At a limit, above all of these: compound 3.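

In the HUVEC assay, chloro in place of hydrogen gives a 1.8-fold lower number from compound 1 to compound 4 (0.25 log units; within the scatter), so this position accepts a group without a change beyond the scatter, which neither methyl nor methoxy did in compound 2 and compound 3. Chloro in place of methyl gives a 7.6-fold lower number from compound 2 to compound 4 (0.88 log units; beyond the scatter). Chloro in place of methoxy gives an at least 2000-fold lower number from compound 3 to compound 4 (3.30 log units; beyond the scatter), so the effect at this position depends on the group, and the loss seen with methoxy does not extend to chloro.

In a physicochemical assay for solubility, at pH 6.8 (on this read-out higher numbers stand for higher solubility and lower numbers for lower solubility), compound 3 gives < 1000 nM and this is a limit of the assay, not a number. In the physicochemical assay compound 4 gives < 1000 nM and this too is a limit of the assay, not a number. From the compounds shown here alone, the step in the physicochemical assay from compound 3 to compound 4 cannot be read, because both values are limits: the limit of < 1000 nM in the physicochemical assay, at which 2 of the 2 values shown sit. Whether fluoro, a nitrile or an amine at this position would match chloro in the HUVEC assay remains open.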